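The source may hold more compounds than are shown below. What is called first, only, known or untested is meant among the compounds shown, and "the series" means these compounds.

For the measured compounds named here, in a functional assay (Nicotiana tabacum) (on this read-out lower numbers stand for stronger inhibition and higher numbers for weaker inhibition), compound 1 `CCCCCNc1nc(SC)nc2ncccc12` gives 650 nM, the lower of the two numbers measured so far, and compound 2 `CCCCCCCNc1nc(SC)nc2ncccc12` gives 4070 nM. Compound 3 `CSc1nc(NC2CCC2)c2cccnc2n1`, still unmeasured, has cyclobutyl in place of pentyl on a nitrogen on an aromatic ring. Going by the values given here, only one measured step bears on this change: a 6.3-fold higher number from compound 1 to compound 2 (0.80 log units; beyond the scatter), a modest step beyond the scatter. It replaces pentyl with a longer chain and tests no ring, so the direction remains uncertain. A modest rise is tentatively expected, with an estimated step of a 2.0-fold higher number from compound 1 to compound 3 (0.30 log units; within the scatter). The expected value for compound 3 is 1300 nM, with an estimated range from 350 nM to 5000 nM.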

Compound 3, half-maximal inhibitory concentration: 720 nM
Estimate against measurement, compound 3: 1.8-fold (0.26 log units) above; the range from low to high includes it.
By their numbers in this assay, from the lowest: compounds 1 and 3 (each within the scatter of the next); then compound 2.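

In this assay, cyclobutyl in place of pentyl on a nitrogen on an aromatic ring gives a 1.1-fold higher number from compound 1 to compound 3 (0.04 log units; within the scatter), so the two groups cannot be told apart on this read-out. The earlier compounds shown here had tested only a longer chain at this position; this result shows that a four-membered ring of carbon only can stand there with no change beyond the scatter. Nothing at hand explains why the two groups read alike. As far as these compounds go, whether cyclopropyl or cyclohexyl would read the same remains open, as does the effect of a shorter chain such as propyl.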